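The compounds below may be only part of what the source reports. "The series", "measured", "known", "first", "only" and "open" are said of these compounds alone.

The two measured compounds share one core and part ways only in the group on the aromatic ring. Among the compounds with values here, compound 1 `O=C1CSC(c2c(Cl)cccc2Cl)N1CCN1CCCCC1` is the first; in an ADME assay on Vero cells (Chlorocebus sabaeus) for cytotoxicity, read by neutral red uptake, tested at 197 ug/mL (on this read-out lower numbers stand for a stronger effect and higher numbers for a weaker effect at the one concentration tested), compound 1 gives 75%. Compound 2 `COc1ccc(C2SCC(=O)N2CCN2CCCCC2)cc1` is the second; in this assay compound 2 gives 87%. That is the highest of the two numbers, and so the weaker effect of the pair. The gap between compound 2 and compound 1 is larger than the usual scatter of such measurements, so the order between the two can be trusted.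

Compound 3 `O=C1CSC(c2ccc([N+](=O)[O-])cc2)N1CCN1CCCCC1` has not yet been measured in this assay. It differs from compound 2 in one place (nitro in place of methoxy on an aromatic carbon). Within the data shown here, no measured pair shows what this exchange does to the read-out, so any expectation rests on compound 2 alone and on the change itself. The expected step is a number 7 percentage points lower from compound 2 to compound 3 (within the scatter), a small move downward that stays within the scatter, if there is any move at all. Compound 3 is therefore estimated at 80%, within a range from 60% to 95%.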

Compound 3, a percentage reported as activity, at one concentration (the size of the read-out at that concentration, not a potency): 72%
Compound 3: middle estimate off by 8 percentage points, on the high side; the measured number falls inside the stated range.
By their numbers in this assay, from the lowest: compounds 3 and 1 (each within the scatter of the next); then compound 2.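

In this assay, nitro in place of methoxy on an aromatic carbon, para to a large group, gives a number 15 percentage points lower from compound 2 to compound 3 (beyond the scatter). Within the data shown here, this is the first exchange made in one place only, with everything else in the molecule held the same, so it shows that the read-out responds to what sits at this position. Lower numbers here stand for a stronger effect at the one concentration tested, so this exchange moves the read-out toward a stronger effect, though the result comes from a single pair and nothing shown here explains it.

From the compounds shown here alone, with only methoxy and nitro compared directly at this position, it remains open where other groups would fall, such as an amine, a carboxylic acid or a longer chain ending in an ether oxygen. Going by these compounds, it also remains open whether the same exchange would give a step of similar size and direction on a different core, or at another carbon of the same aromatic ring.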